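Swapping trifluoromethyl for carboxy on a shared core

The compounds below may be only part of what the source reports. "The series", "measured", "known", "first", "only" and "open" are said of these compounds alone.

Compound 1 `Cc1n[nH]c(C(=O)O)c1Cc1cccc(-c2ccc(C#N)cc2)c1` gives 46% in an assay on isolated protein for inhibition of 2-Hydroxyacid oxidase 2 (Homo sapiens), tested at 10 uM; on this read-out lower numbers stand for a weaker effect and higher numbers for a stronger effect at the one concentration tested.
Compound 2 `Cc1n[nH]c(C(=O)O)c1Cc1cccc(-c2ccccc2F)c1` gives 22% in this assay.
Compound 3 `Cc1n[nH]c(C(=O)O)c1Cc1cccc(C(F)(F)F)c1` gives 23% in this assay.

All three compounds share one core and differ only in the group attached to one aromatic carbon. On the numbers shown, compound 3 stands second highest of three, but its nearest neighbour is compound 2, and a number 1 percentage points higher from compound 2 to compound 3 (within the scatter), so these two cannot be told apart. For the measured compounds named here, the only changes beyond the scatter come from giving up the 4-cyanophenyl group: a number 24 percentage points lower from compound 1 to compound 2 (beyond the scatter) and a number 23 percentage points lower from compound 1 to compound 3 (beyond the scatter).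

Compound 4 `Cc1n[nH]c(C(=O)O)c1Cc1cccc(C(=O)O)c1` has not yet been measured. It differs from compound 3 in one place: carboxy in place of trifluoromethyl on an aromatic carbon. The measured steps bear on this only loosely. Going by the values given here, the large drops came from removing the 4-cyanophenyl group, which compound 3 already lacks, while the one measured step between two compounds carrying a small group in that place stayed within the scatter. Among the compounds with values here, no measured step exchanges one such small group for another, so nothing here points in a set direction. A change of no size beyond the scatter is therefore expected, a number 3 percentage points lower from compound 3 to compound 4 (within the scatter). Compound 4 is estimated at 20%, with a range from 5% to 40%.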

Compound 4, a percentage reported as inhibition, at one concentration (the size of the read-out at that concentration, not a potency): 0%
The estimate for compound 4 lay 20 percentage points above the measured number, and the stated range ends above it.
By their numbers in this assay, from the lowest: compound 4; then compounds 2 and 3 (each within the scatter of the next); then compound 1.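

Placed on this aromatic carbon, the choice between two small groups can matter: in this assay, exchanging trifluoromethyl for carboxy gives a number 23 percentage points lower from compound 3 to compound 4 (beyond the scatter), whereas the earlier compounds had shown only that losing the 4-cyanophenyl group lowered the number. Carboxy also falls short of the 2-fluorophenyl group, with a number 22 percentage points lower from compound 2 to compound 4 (beyond the scatter), so compounds 2 and 3, which sit within the scatter of each other, both stand clearly above compound 4. Measured against the 4-cyanophenyl group, the change is large, a number 46 percentage points lower from compound 1 to compound 4 (beyond the scatter), and compound 4 gives 0%, which means that no inhibition is recorded for it at the one concentration tested.

Why carboxy behaves this way at this place remains unexplained, as no accompanying measurement speaks to the cause. On these data alone, it also remains open whether the loss belongs to carboxy alone or would also appear with a related group here, such as a methyl ester, a primary amide or an amine, and whether carboxy would cost as much if carried further out on a phenyl ring.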